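A few compounds are considered here, and "the series" means these few. Any claim that something is new, unique, unknown or untested is made for them only; others in the source may bear on it.

Measured in a functional assay on Hep 3B2 cells (Homo sapiens) for inhibition, read by MTT assay, with a stated time of 72 h; a higher number here means a weaker inhibitor, a lower number a stronger inhibitor:
- Compound 1 `Nc1ncnc2c1c(-c1cnc3[nH]ccc3c1)nn2CCCCCC(=O)NO`: > 50000 nM, a limit
- Compound 2 `Nc1nc2cc(-c3nn(CCCCCCCCCC(=O)NO)c4ncnc(N)c34)ccc2o1`: 28800 nM
- Compound 3 `Nc1ncnc2c1c(-c1cnc3[nH]ccc3c1)nn2CCCCCCCCCC(=O)NO`: 17200 nM

Among the compounds with values here, compound 2 holds one of the only two true numbers in this set, and a 1.7-fold lower number from compound 2 to compound 3 (0.22 log units; within the scatter) leaves it level with compound 3. The value of compound 1 is a limit of the assay, not a number.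

Compound 4 `Nc1nc2cc(-c3nn(CCCCC(=O)NO)c4ncnc(N)c34)ccc2o1` keeps the core of compound 2 but differs in its chain: hydroxycarbamoyl in place of 5-(hydroxycarbamoyl)pentyl on a saturated chain carbon, four bonds along the chain from an aromatic nitrogen. The step that bears on this most directly is an at least 2.9-fold lower number from compound 1 to compound 3 (0.46 log units; beyond the scatter), which adds 4-(hydroxycarbamoyl)butyl in place of hydroxycarbamoyl on the other core. Compound 4 makes a change of the same kind in the opposite direction, so a higher number is expected in this assay. The step to compound 3 from compound 2 suggests that the two cores can be compared, though only these few compounds support this.

Compound 4 may be reported only against (the limit of > 50000 nM in this assay, at which 1 of the 3 values shown sits).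

The expected change is a 2.4-fold higher number from compound 2 to compound 4 (0.39 log units; beyond the scatter).

The estimate for compound 4 is 70000 nM, with an expected range of 30000 nM to 160000 nM.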

Compound 4, half-maximal inhibitory concentration: 33700 nM
The estimate for compound 4 lay 2.1-fold (0.32 log units) above the measured number; low and high end bracket the measured number.
By their numbers in this assay, from the lowest: compounds 3, 2 and 4 (each within the scatter of the next). At a limit, above all of these: compound 1.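

Putting hydroxycarbamoyl in place of 5-(hydroxycarbamoyl)pentyl at this position gives, in this assay, a 1.2-fold higher number from compound 2 to compound 4 (0.07 log units; within the scatter), so on this core the long and short chains stand level. The earlier compounds had shown a chain step beyond the scatter only on the other core, an at least 2.9-fold lower number from compound 1 to compound 3 (0.46 log units; beyond the scatter), and the present result does not repeat that step here. Compound 1 in that earlier step stands at a limit, not a number, so the size of that step stays unfixed: the limit of > 50000 nM in this assay, at which 1 of the 4 values shown sits.

From the compounds shown here alone, whether a chain of intermediate length or a longer chain on this core would stay level with these two remains open. Also open, going by these compounds, is whether a carboxylic acid or an amine in place of the hydroxycarbamoyl end would give a different number in this assay.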